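Removing the chlorine from compound 2: what to expect

The source may report more compounds than this note shows. Statements on the series, on what has been measured and on what is new or still open speak of the compounds shown alone.

Measured compounds:
compound 1 `Cc1ccc2occ(C3N=C(c4ccccc4)SS3)c(=O)c2c1` — 66500 nM
compound 2 `O=c1c(C2N=C(c3ccccc3)SS2)coc2cc(Cl)ccc12` — 57500 nM

Both compounds were tested in a functional assay on A549 cells (Homo sapiens) for inhibition, read by sulforhodamine B assay, with a stated time of 48 h; on this read-out lower numbers stand for stronger inhibition and higher numbers for weaker inhibition. Compound 2 gives 57500 nM, the lowest of the two numbers, but its nearest neighbour, compound 1 with 66500 nM, sits within the scatter of repeated measurements, so the two cannot be told apart in potency.

Compound 3 `O=c1c(C2N=C(c3ccccc3)SS2)coc2ccccc12` has not yet been measured in this assay. Relative to compound 2 the change is hydrogen in place of chloro on an aromatic carbon. For the measured compounds named here, no measured pair in this set shows what such a change does here, so there is no step to lean on. Compound 3 is therefore expected to land near compound 2, with a step from compound 2 that may fall within the scatter or be modestly weaker: a 1.3-fold higher number from compound 2 to compound 3 (0.12 log units; within the scatter). The estimate for compound 3 is 75000 nM, with a range of 25000 nM to 220000 nM.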

Compound 3, half-maximal inhibitory concentration: > 100000 nM
Compound 3: only a limit was reported; the forecaster's own chance of this, stated with the estimate: 20%; middle value at least 1.3-fold (0.12 log units) from the limit.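

In this assay compound 3, which has hydrogen on this aromatic carbon, gives > 100000 nM, a limit of the assay and not a number. For the compounds shown here, this yields the first readable steps for removing a group from the aromatic ring, an at least 1.7-fold higher number from compound 2 to compound 3 (0.24 log units; that floor lies within the scatter) and an at least 1.5-fold higher number from compound 1 to compound 3 (0.17 log units; that floor lies within the scatter), so both point the same way, but each is known only as a floor and its true size could be larger. The two compounds with a ring substituent therefore give numbers, while the one without a substituent reaches the limit of the read-out: the limit of > 100000 nM in this assay, at which 1 of the 3 values shown sits.

What the compounds shown leave open is how far compound 3 really lies from compound 1 and compound 2. Going by these compounds, it is also open whether a different group on this aromatic carbon, such as an amine or a methoxy group, would read like chloro.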